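Swapping Iodo for Trifluoromethyl on a Second Core

A few compounds are considered here, and "the series" means these few. Any claim that something is new, unique, unknown or untested is made for them only; others in the source may bear on it.

Compound 1 `O=C(N/N=C/C1=C(Cl)c2ccccc2CCC1)c1cccc(I)c1` and compound 2 `O=C(N/N=C/C1=C(Cl)c2ccccc2CCC1)c1cccc(C(F)(F)F)c1` share one core, while compound 3 `Cc1cc2c(cc1C)C(Cl)=C(/C=N/NC(=O)c1cccc(I)c1)CCC2` carries a core whose difference from the core of compound 1 is not broken down here. In a functional assay on MDA-MB-231 cells (Homo sapiens) for inhibition, read by sulforhodamine B assay, with a stated time of 48 h (on this read-out higher numbers stand for weaker inhibition of growth and lower numbers for stronger inhibition of growth), compound 1 gives 55200 nM and compound 2 gives 94300 nM; the change between them is trifluoromethyl in place of iodo on an aromatic carbon, and it made a 1.7-fold higher number from compound 1 to compound 2 (0.23 log units; within the scatter). In this assay compound 3 gives 1200 nM, the lowest number of the three. Compound 4 `Cc1cc2c(cc1C)C(Cl)=C(/C=N/NC(=O)c1cccc(C(F)(F)F)c1)CCC2` repeats that change on the core of compound 3: trifluoromethyl in place of iodo on an aromatic carbon. Because the earlier pair showed a 1.7-fold higher number from compound 1 to compound 2 (0.23 log units; within the scatter), a step of similar size is expected here, a 1.7-fold higher number from compound 3 to compound 4 (0.22 log units; within the scatter). Compound 4 is therefore estimated at 2000 nM, with a range from 900 nM to 4500 nM in this assay.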

Compound 4, concentration for 50% growth inhibition: < 10 nM
Compound 4: only a limit was reported; the forecaster's own chance of this, stated with the estimate: 2%; at least 200-fold (2.30 log units) between middle value and limit.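

Trifluoromethyl in place of iodo gives an at least 120-fold lower number from compound 3 to compound 4 (2.07 log units; beyond the scatter) in this assay, so the step seen on one core did not carry over to the other: the same change on two cores in this assay, a 1.7-fold higher number (0.23 log units; within the scatter) from compound 1 to compound 2 and an at least 120-fold lower number (2.07 log units; beyond the scatter) from compound 3 to compound 4, at least 200-fold (2.31 log units) apart, beyond the scatter of two such steps

The result for compound 4, < 10 nM, is a limit of the assay and not a number: the limit of < 10 nM in this assay, at which 1 of the 4 values shown sits.

For the compounds shown here, two cores show only that this change can behave very differently from one core to another; they do not show why, or what it would do on a further core.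

The compounds shown carry only iodo and trifluoromethyl at this place on the ring. From the compounds shown here alone, it remains open how a nitrile, a methoxy group or an amine there would behave on either core.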